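Swapping a Pyridinyl for a Trifluoromethylphenyl on the Alkyne

The source may report more compounds than this note shows. Statements on the series, on what has been measured and on what is new or still open speak of the compounds shown alone.

The three measured compounds share a methoxyamino-purine nucleoside core in compounds 2 and 3, whereas compound 1 `CCC(=O)[C@H]1O[C@@H](n2cnc3c(N)nc(C#Cc4ccccc4)nc32)[C@H](O)[C@@H]1O` carries a different sugar and an amino group and, in an assay on CHO cells for displacement of a labelled ligand from adenosine receptor A1 (Homo sapiens) (a higher number here means a weaker inhibitor, a lower number a stronger inhibitor), compound 1 gives 3920 nM. Compound 2 `CONc1nc(C#CCCCC#N)nc2c1ncn2[C@@H]1O[C@H](CO)[C@@H](O)[C@H]1O` gives 282 nM in this assay, and compound 3 `CONc1nc(C#Cc2ccccn2)nc2c1ncn2[C@@H]1O[C@H](CO)[C@@H](O)[C@H]1O` gives 437 nM. Compound 3 thus has the second highest of the three numbers; it sits closest to compound 2 and furthest from compound 1.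

Compound 4 `CONc1nc(C#Cc2cccc(C(F)(F)F)c2)nc2c1ncn2[C@@H]1O[C@H](CO)[C@@H](O)[C@H]1O` differs from compound 3 in one place: 3-(trifluoromethyl)phenyl in place of pyridin-2-yl on a triple-bonded carbon. For the measured compounds named here, the only measured step on the same position, a 1.5-fold higher number from compound 2 to compound 3 (0.19 log units; within the scatter), stayed within the scatter, so the data give no sign that the group on the triple-bonded carbon moves the number much. Compound 1 also bears an aromatic ring on the alkyne but differs elsewhere, so only its value is noted. Compound 4 is therefore expected to show a 1.2-fold lower number from compound 3 to compound 4 (0.06 log units; within the scatter), a step not beyond the scatter. The estimate for compound 4 in this assay is 380 nM, with a range from 120 nM to 1200 nM.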

Compound 4, inhibition constant: 2450 nM
Compound 4: middle estimate off by 6.4-fold (0.81 log units), on the low side, and the stated range ends below it.
By their numbers in this assay, from the lowest: compounds 2 and 3 (each within the scatter of the next); then compounds 4 and 1 (each within the scatter of the next).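

In this assay, the group on the triple-bonded carbon proves able to move the number: 3-(trifluoromethyl)phenyl in place of pyridin-2-yl gives a 5.6-fold higher number from compound 3 to compound 4 (0.75 log units; beyond the scatter), and in place of 3-cyanopropyl it gives an 8.7-fold higher number from compound 2 to compound 4 (0.94 log units; beyond the scatter). The position is therefore not indifferent to its group, although the earlier change from 3-cyanopropyl to pyridin-2-yl, a 1.5-fold higher number from compound 2 to compound 3 (0.19 log units; within the scatter), suggested that it might be. Nothing available explains the shift.

As far as these compounds go, the step to compound 4 removes the ring nitrogen and adds the trifluoromethyl group at once, so the share of each stays open. On the shared core of compound 3, a plain phenyl ring on the triple-bonded carbon, or a phenyl ring carrying an amine instead of trifluoromethyl, would bear on that question.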